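A few compounds are considered here, and "the series" means these few. Any claim that something is new, unique, unknown or untested is made for them only; others in the source may bear on it.

Three members of the series have been measured. In a functional assay with Alpha-1B adrenergic receptor (Homo sapiens) as the target, read by calcium flux (a higher number here means a larger maximal response, a lower number a smaller maximal response), compound 1 `Cc1ccc(-c2ccccc2NCC2=NCCN2)n1C` gives 0%, compound 2 `Cn1cccc1-c1ccccc1NCC1=NCCN1` gives 0%, and compound 3 `Cc1n[nH]c(-c2ccccc2NCC2=NCCN2)n1` gives 0%. Compound 2 thus stands level with compounds 1 and 3 at the digits shown: the step of no change at the digits printed from compound 1 to compound 2 (within the scatter) and the step of no change at the digits printed from compound 2 to compound 3 (within the scatter) both stay within the scatter. Compound 4 `CCn1cccc1-c1ccccc1NCC1=NCCN1` remains to be measured in this assay; relative to compound 2 the change is methyl in place of hydrogen on a saturated chain carbon bound to an aromatic nitrogen. Neither measured step touches this place, and neither moved the read-out, so no step beyond the scatter is expected here either. Compound 4 is therefore expected to give 0%, between 0% and 10%. The corresponding step is estimated at no change at the digits printed from compound 2 to compound 4 (within the scatter).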

Compound 4, largest response reached (reported as maximal response), in percent of the reference or control that the assay uses: 0%
Compound 4: the middle estimate sits on the measured number at the digits printed, and the stated range covers the measured number.
By their numbers in this assay, from the lowest: compounds 1, 2, 3 and 4 (each within the scatter of the next).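

Within the data shown here, this is the first reading at this position: in this assay, going from methyl to ethyl on the saturated chain carbon bound to an aromatic nitrogen gives no change at the digits printed from compound 2 to compound 4 (within the scatter). One added methyl at this place therefore does not lift compound 4 off the level of the other compounds, with compound 4 at 0%. No supporting data bear on this result.

Still open, going by these compounds, is whether a longer chain, such as propyl, or a terminal amine or carboxylic acid at this place would give any measurable maximal response.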